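The source may report more compounds than this note shows. Statements on the series, on what has been measured and on what is new or still open speak of the compounds shown alone.

Working notes on the series. Within the data shown here, in an assay on isolated protein (Cavia porcellus) with Sigma non-opioid intracellular receptor 1 (Homo sapiens) as the target, read by radioligand binding (on this read-out lower numbers stand for stronger inhibition and higher numbers for weaker inhibition), compound 1 `CN(C)CCCCOc1ccc2oc(-c3ccccc3)cc(=O)c2c1` gives 720 nM, the highest of the three numbers measured so far. Compound 2 `CN(C)CCCCCCCOc1ccc2oc(-c3ccccc3)cc(=O)c2c1` gives 165 nM in this assay, and compound 3 `CN(C)CCCCCCCCOc1ccc2oc(-c3ccccc3)cc(=O)c2c1` gives 227 nM in this assay. Both measured steps out of compound 1 extend the chain between the aromatic oxygen and the dimethylamino nitrogen and lower the number modestly: a 4.4-fold lower number from compound 1 to compound 2 (0.64 log units; beyond the scatter) and a 3.2-fold lower number from compound 1 to compound 3 (0.50 log units; beyond the scatter). Between the two longer chains the difference is a 1.4-fold higher number from compound 2 to compound 3 (0.14 log units; within the scatter).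

Compound 4 `O=c1cc(-c2ccccc2)oc2ccc(OCCCN3CCC(O)CC3)cc12` is not yet measured. It differs from compound 1 by 4-hydroxypiperidin-1-yl in place of (dimethylamino)methyl on a saturated chain carbon, three bonds along the chain from an oxygen on an aromatic ring. Among the measured compounds shown here, no measured step covers exchanging the open dimethylamino for a ring amine, nor the hydroxyl that comes with it; the only steps that bear on the change concern chain length, and they were modest in size. On that footing the estimate for compound 4 in this assay is 600 nM, range 150 nM to 2500 nM. The expected step, a 1.2-fold lower number from compound 1 to compound 4 (0.08 log units; within the scatter), is therefore not beyond the scatter in either direction.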

Compound 4, half-maximal inhibitory concentration: 130 nM
The estimate for compound 4 lay 4.6-fold (0.66 log units) above the measured number; the measured number lies below the stated range.
By their numbers in this assay, from the lowest: compounds 4, 2 and 3 (each within the scatter of the next); then compound 1.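

At this place, 4-hydroxypiperidin-1-yl in place of (dimethylamino)methyl gives a 5.5-fold lower number from compound 1 to compound 4 (0.74 log units; beyond the scatter), so a change to the amine itself, and not only a longer chain, can move the number away from that of compound 1. Among these compounds, the ring amine on the shorter chain also sits level with both long-chain dimethylamino compounds, with a 1.3-fold lower number from compound 2 to compound 4 (0.10 log units; within the scatter) and a 1.7-fold lower number from compound 3 to compound 4 (0.24 log units; within the scatter), so a long chain is not the only route to numbers in this range. Nothing available explains the size of this step.

Among the compounds shown here, the single change brings in the ring and the hydroxyl together, so their shares stay unresolved; piperidin-1-yl without the hydroxyl on the same chain would separate them. Also open, going by these compounds, is whether 4-hydroxypiperidin-1-yl on a longer chain adds to the step or merely matches it.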